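Swapping the pyridine substituent ahead of a trypsin check

This account rests on a few compounds, and the source may have more. Where it says the series, first, only, none or still open, it means among the compounds named here.

Compound 1 `Cc1nn(-c2cccc(CN)c2)c2c(F)c(-c3ccc(N4CCCC4=O)cc3)ccc12` has been measured in an assay on isolated protein for inhibition of Trypsin (Homo sapiens) (on this read-out lower numbers stand for stronger inhibition and higher numbers for weaker inhibition), where compound 1 gives 702 nM. Compound 2 `Nc1noc2ccc(-n3nc(C(F)(F)F)c4ccc(-c5ccc(N6CCCCC6=O)cc5F)c(F)c43)cc12` was run in the same way. For compound 2 the read-out is only a limit of the assay, > 10000 nM. Compound 3 `CN(C)Cc1ccncc1-c1ccc(-c2ccc3c(C(N)=O)nn(-c4ccc5onc(N)c5c4)c3c2F)c(F)c1` likewise gives no number. In this assay compound 3 reaches only a limit, > 10000 nM. Compound 3 therefore stands where most of the shown values sit, at the limit of > 10000 nM in this assay, at which 2 of the 3 values shown sit, and only compound 1 yields a number.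

Compound 4 `CN(C)CCN(c1cccnc1)c1ccc(-c2ccc3c(C(N)=O)nn(-c4ccc5onc(N)c5c4)c3c2F)c(F)c1` has not yet been measured. It differs from compound 3 in one place: (2-(dimethylamino)ethyl)(pyridin-3-yl)amino in place of 4-((dimethylamino)methyl)pyridin-3-yl on an aromatic carbon. In words, (2-(dimethylamino)ethyl)(pyridin-3-yl)amino in place of 4-((dimethylamino)methyl)pyridin-3-yl on an aromatic carbon. Going by the values given here, no pair of measured compounds shows an exchange of this kind, so the size of its effect cannot be read from the data. With compound 3 already at the limit, the expectation is that the change moves the result by nothing beyond the usual scatter, and the expected step is a step that the limit leaves unreadable from compound 3 to compound 4. For compound 4 the estimate in this assay is 15000 nM, within a range from 4000 nM to 60000 nM, and the measurement is expected most often to come back as a limit rather than a number.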

Compound 4, inhibition constant: > 10000 nM
Compound 4 gave a limit, no number; the forecaster's own chance of this, stated with the estimate: 80%; the middle value lies beyond the limit too.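

Compound 3 and compound 4 both return only a limit in this assay, not a number, so no step can be read between them. Most of the values shown are of this kind: the limit of > 10000 nM in this assay, at which 3 of the 4 values shown sit.

The compounds shown leave open whether exchanging 4-((dimethylamino)methyl)pyridin-3-yl for (2-(dimethylamino)ethyl)(pyridin-3-yl)amino shifts the result in this assay at all, and by how much.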